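The source may report more compounds than this note shows. Statements on the series, on what has been measured and on what is new or still open speak of the compounds shown alone.

For the measured compounds named here, in an in vitro ADME assay on microsomes from liver (Simiiformes) (on this read-out lower numbers stand for a shorter-lived compound and higher numbers for a longer-lived compound), only two compounds have numbers so far. Compound 1 `CC(=O)c1ccc(CCCOc2c(C)cc(-c3noc(C(F)(F)F)n3)cc2C)o1` gives 1.05 h, and compound 2 `Cc1cc(CCCOc2c(C)cc(-c3noc(CC(F)(F)F)n3)cc2C)on1` gives 0.533 h. These two values lie within the usual scatter of each other, so compound 2 cannot be told apart from compound 1 on this read-out. Going by the values given here, their structures differ in more than one place, so no measured step shows what a single change does here. Compound 3 `Cc1cc(CCCOc2c(C)cc(-c3noc(C(F)F)n3)cc2C)on1` has not been measured yet. On an aromatic carbon of a five-membered aromatic ring with 2 nitrogen and 1 oxygen, it carries difluoromethyl in place of 2,2,2-trifluoroethyl on an aromatic carbon. The data point in neither direction, so no change beyond the scatter is expected, and the estimated step is a 1.1-fold higher number from compound 2 to compound 3 (0.05 log units; within the scatter). In this assay compound 3 is expected at 0.6 h, within a range of 0.3 h to 1.2 h.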

Compound 3, half-life: 1.42 h
Estimate against measurement, compound 3: 2.4-fold (0.37 log units) below; the measured number lies above the stated range.
By their numbers in this assay, from the lowest: compounds 2, 1 and 3 (each within the scatter of the next, the first and the last beyond it).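

For the compounds shown here, this is the first measured step that changes one place only: on an aromatic carbon of the five-membered aromatic ring, difluoromethyl in place of 2,2,2-trifluoroethyl gives a 2.7-fold higher number from compound 2 to compound 3 (0.43 log units; beyond the scatter) in this assay. The half-life therefore responds to the group at this position, since swapping one fluorine-bearing group for another, with the rest of compound 2 unchanged, moves it beyond the scatter. No measurement shown here explains the step.

Compound 1 carries trifluoromethyl at this place but also differs elsewhere, so it cannot show how much the chain or the number of fluorines matters. Also open, as far as these compounds go, is how a plain methyl or ethyl group, with no fluorine, or an amine would read at this place on the same core.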